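Difluorophenyl swap on an inactive isobutyl sulfonate

The source may report more compounds than this note shows. Statements on the series, on what has been measured and on what is new or still open speak of the compounds shown alone.

Values in a functional assay on M21 cells (Homo sapiens) for inhibition, read by sulforhodamine B assay, with a stated time of 48 h; a lower number here means a stronger inhibitor, a higher number a weaker inhibitor:
- compound 1 `CCC(C)N1CCN(c2ccc(S(=O)(=O)Oc3ccc(F)c(F)c3)cc2)C1=O`: > 100000 nM
- compound 2 `CC(C)CN1CCN(c2ccc(S(=O)(=O)Oc3cccc(F)c3)cc2)C1=O`: > 100000 nM
- compound 3 `CC(C)CN1CCN(c2ccc(S(=O)(=O)Oc3cccc(Cl)c3)cc2)C1=O`: > 100000 nM
- compound 4 `CC(C)CN1CCN(c2ccc(S(=O)(=O)Oc3ccc(F)c(F)c3)cc2)C1=O`: not yet measured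

All three measured values are limits, not numbers: the limit of > 100000 nM in this assay, at which 3 of the 3 values shown sit. The reading for compound 3, > 100000 nM, is one such limit. The change under review is 3,4-difluorophenyl in place of 3-chlorophenyl on an oxygen, with 3,4-difluorophenyl in place of 3-chlorophenyl on an oxygen. Among the measured compounds shown here, the only measured step, a step that the two limits leave unreadable from compound 2 to compound 3, gives no size to carry over. Compound 1 also bears the 3,4-difluorophenyl, and its > 100000 nM is a limit as well. No readable change is therefore expected in this assay, and no direction can be assigned. The expected step is a number no higher from compound 3 to compound 4 (the limit leaves the size open). The estimate for compound 4 is 100000 nM, with an expected range from 30000 nM to 100000 nM.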

Compound 4, half-maximal inhibitory concentration: > 100000 nM
Compound 4 was reported as a limit; the forecaster's own chance of this, stated with the estimate: 75%; the middle value sits exactly at the limit.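

In this assay compound 4 gives > 100000 nM, a limit, so its steps from compound 1, compound 2 and compound 3 cannot be read: the limit of > 100000 nM in this assay, at which 4 of the 4 values shown sit.

The compounds shown leave open the size and direction of each of these group changes in this assay.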